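The source may report more compounds than this note shows. Statements on the series, on what has been measured and on what is new or still open speak of the compounds shown alone.

Compound 1 `C/N=C(/S)C1=CC(C)(C)Oc2ccc([N+](=O)[O-])cc21`: 1.35 nM
Compound 2 `CNC(=O)C1=CC(C)(C)Oc2ccc([N+](=O)[O-])cc21`: 10.7 nM
Compound 3 `CNC(=O)C1=CC(C)(CF)Oc2ccc([N+](=O)[O-])cc21`: 8.91 nM
Compound 4 `CC1(C)C=C(/C(S)=N\CCC#N)c2cc([N+](=O)[O-])ccc2O1`: not yet measured

The values above come from a functional assay (aorta) with Rattus norvegicus as the target; a lower number here means that less compound is needed, a higher number that more compound is needed for the effect. Compound 2 stands level with compound 3, the two lying within the scatter of each other, while compound 1 has a clearly lower number.

Going from compound 2 to compound 4 changes one place: a group of 7 heavy atoms (4 carbon, 2 nitrogen, 1 sulfur; no ring) in place of a group of 4 heavy atoms (2 carbon, 1 nitrogen, 1 oxygen; no ring), on a double-bonded ring carbon. Methylcarbamoyl leaves, and the group that enters has sulfur and no oxygen, plus a triple bond that methylcarbamoyl lacks. It sits on a double-bonded ring carbon.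

The closest guide is the pair of compound 1 and compound 2, which differ in a group with sulfur against one with oxygen at this same kind of carbon: a 7.9-fold higher number from compound 1 to compound 2 (0.90 log units; beyond the scatter). Read backwards, that step points to a lower number for the sulfur group. The other measured step, a 1.2-fold lower number from compound 2 to compound 3 (0.08 log units; within the scatter), concerns a different place and says little here. For the measured compounds named here, no measured compound shows what the longer chain does, so part of that gain may be lost or kept.

A lower number is therefore expected, in a smaller step than the sulfur pair showed. The estimated step is a 3.6-fold lower number from compound 2 to compound 4 (0.55 log units; beyond the scatter). For compound 4 the estimated value is 3 nM, with an expected range from 0.7 nM to 13 nM.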

Compound 4, half-maximal effective concentration: 0.372 nM
The estimate for compound 4 lay 8.1-fold (0.91 log units) above the measured number, and the stated range ends above it.
By their numbers in this assay, from the lowest: compound 4; then compound 1; then compounds 3 and 2 (each within the scatter of the next).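

In this assay, for the compounds shown here, the earlier compounds showed only that the sulfur group with a short chain gives a lower number than methylcarbamoyl at this double-bonded ring carbon, and they could not show what a longer chain would do. Extending that chain does not use up the gain, since cyanomethyl in place of hydrogen on the saturated chain carbon bound to the double-bonded nitrogen gives a 3.6-fold lower number from compound 1 to compound 4 (0.56 log units; beyond the scatter), and the full exchange of methylcarbamoyl for the new group adds up to a 29-fold lower number from compound 2 to compound 4 (1.46 log units; beyond the scatter), a large step at this position. No measurement shown here gives a reason for this drop.

The compounds shown leave open whether the nitrile matters or chain length alone is enough, which a plain propyl chain or a chain ending in an amine would help to separate. From the compounds shown here alone, it also remains open whether the same chain would lower the number on the carbonyl form of the group, or whether fluoro on the saturated chain carbon of compound 3 would make any difference alongside the sulfur group.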